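A few compounds are considered here, and "the series" means these few. Any claim that something is new, unique, unknown or untested is made for them only; others in the source may bear on it.

Compound 1 `CC1=Nc2c(O)nc(N)nc2OC1C`: 377000 nM
Compound 2 `CC1=Nc2c(O)nc(N)nc2OC1c1ccccc1`: 740000 nM

Both numbers come from an assay on isolated protein for inhibition of Dihydrofolate reductase (Homo sapiens), read by spectrophotometry; a higher number here means a weaker inhibitor, a lower number a stronger inhibitor. Compound 1 stands at the lowest of the two numbers, but the step of a 2.0-fold higher number from compound 1 to compound 2 (0.29 log units; within the scatter) is within the scatter, so the two cannot be told apart. Compound 3 `CC1=Nc2c(N)nc(N)nc2OC1C` differs from compound 1 by amino in place of hydroxy on an aromatic carbon. For the measured compounds named here, the only measured step swaps a group on a saturated ring carbon, so no measured step bears on a change at an aromatic carbon, and the size of this step cannot be read from the data. With that caveat, compound 3 is estimated at 150000 nM, between 15000 nM and 700000 nM, an expected step of a 2.5-fold lower number from compound 1 to compound 3 (0.40 log units; beyond the scatter).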

Compound 3, half-maximal inhibitory concentration: 903000 nM
Compound 3: the middle estimate sits 6.0-fold (0.78 log units) below what was measured; the measured number lies above the stated range.
By their numbers in this assay, from the lowest: compounds 1, 2 and 3 (each within the scatter of the next, the first and the last beyond it).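

For the compounds shown here, at this aromatic carbon, next to the ring nitrogen, amino in place of hydroxy gives the first measured step beyond the scatter in this assay (a 2.4-fold higher number from compound 1 to compound 3 (0.38 log units; beyond the scatter)), though it is modest and leaves a weaker inhibitor. Hydroxy and amino have the same counts of heavy atoms, hydrogen-bond donors and acceptors, so those counts alone do not fix the number here. No available evidence accounts for this shift.

The compounds shown leave open how a methoxy group or a chlorine atom would fare at this carbon. From the compounds shown here alone, it also remains open whether the amino step would hold with phenyl on the saturated ring carbon.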